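The source may report more compounds than this note shows. Statements on the series, on what has been measured and on what is new or still open speak of the compounds shown alone.

The compounds here share one core. Compound 1 `CCOC(=O)c1sc(-c2cccc(NC(=O)c3ccccc3)c2)nc1Nc1ccc(N2CCN(C)CC2)cc1` pairs an ethyl ester with a plain benzamide, and in a functional assay on Raji cells (Homo sapiens) for antiproliferative activity, read by CCK-8 assay, with a stated time of 72 h (a lower number here means a stronger inhibitor, a higher number a weaker inhibitor), compound 1 gives "not determined" (no result reported). Compound 2 `CCOC(=O)c1sc(-c2cccc(NC(=O)c3ccccc3F)c2)nc1Nc1ccc(N2CCN(C)CC2)cc1`, carrying a fluorine in its benzamide, gives 9270 nM in this assay, a weak result. Compound 3 `CN1CCN(c2ccc(Nc3nc(-c4cccc(NC(=O)c5ccccc5)c4)sc3C(=O)O)cc2)CC1` is the free acid of compound 1; in this assay compound 3 gives "not determined" (no result reported), so it stands nowhere on the numbers shown, and only compound 2 offers a figure. Compound 4 `CN1CCN(c2ccc(Nc3nc(-c4cccc(NC(=O)c5ccc(Cl)cc5)c4)sc3C(=O)O)cc2)CC1` differs from compound 3 by one change: chloro in place of hydrogen on an aromatic carbon. Within the data shown here, no measured pair shows such a step, so in this assay only a small step is expected, within the scatter and in no clear direction. Among the measured compounds shown here, the sole reference is compound 2 at 9270 nM, and a similarly weak result is expected. Compound 4 is estimated at 10000 nM, plausibly between 2500 nM and 40000 nM.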

Compound 4, half-maximal inhibitory concentration: 7020 nM
Estimate against measurement, compound 4: 1.4-fold (0.15 log units) above; measured number inside the range.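

In this assay, among these compounds, compound 3 has no single number, so no step to compound 4 can be read. Nothing shown here speaks to a cause. On these data alone, whether the chloro group changes activity, and whether free acid and ethyl ester differ, stays open.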